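This account rests on a few compounds, and the source may have more. Where it says the series, first, only, none or still open, it means among the compounds named here.

Compound 2 `CCSc1nc(N)c2ncn([C@H]3C[C@H](OP(=O)(O)O)[C@@H](COP(=O)(O)O)O3)c2n1` gives the lowest of the two numbers recorded in a functional assay on cell membranes for activation of P2Y purinoceptor 1 (Meleagris gallopavo); a higher number here means that more compound is needed for the effect, a lower number that less compound is needed. In this assay compound 2 gives 1980 nM, and compound 1 `CNc1nc(I)nc2c1ncn2[C@H]1C[C@H](OP(=O)(O)O)[C@@H](COP(=O)(O)O)O1` gives 4440 nM, a gap that lies beyond the scatter. Compound 3 `CCCSc1nc(N)c2ncn([C@H]3C[C@H](OP(=O)(O)O)[C@@H](COP(=O)(O)O)O3)c2n1` has not yet been measured. It differs from compound 2 by methyl in place of hydrogen on a saturated chain carbon, two bonds along the chain from a sulfur, so the ethylsulfanyl group becomes a propylsulfanyl group. Among the compounds with values here, no pair of measured compounds shows the effect of this change in this assay, and compound 1 differs from compound 2 in more than one place, so it offers no guide to this particular step. The expected step from compound 2 to compound 3 is therefore small, a 1.3-fold higher number from compound 2 to compound 3 (0.12 log units; within the scatter), perhaps a slight rise in the number but most likely within the scatter. Compound 3 is estimated to give 2600 nM in this assay, with a range from 900 nM to 7500 nM.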

Compound 3, half-maximal effective concentration: 1710 nM
Compound 3: the middle estimate sits 1.5-fold (0.18 log units) above what was measured; low and high end bracket the measured number.
By their numbers in this assay, from the lowest: compounds 3 and 2 (each within the scatter of the next); then compound 1.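

Within the data shown here, the step to the propylsulfanyl group gives the first direct reading of this change in this assay, with a 1.2-fold lower number from compound 2 to compound 3 (0.06 log units; within the scatter), which lies within the scatter. On a saturated chain carbon, two bonds along the chain from a sulfur, methyl in place of hydrogen thus leaves compound 2 and compound 3 indistinguishable in this measurement, so this position accepts the ethylsulfanyl to propylsulfanyl change with no readable effect. No measurement at hand offers an explanation for this result.

From the compounds shown here alone, whether a longer chain such as butylsulfanyl, a branched group such as isopropylsulfanyl or a benzylsulfanyl group would also stay within the scatter of compound 2 remains open. A single step also cannot show whether the same change would behave alike elsewhere on the shared core.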